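Working notes: methoxy-for-hydrogen steps in one antiproliferative series

A few compounds are considered here, and "the series" means these few. Any claim that something is new, unique, unknown or untested is made for them only; others in the source may bear on it.

Measured so far, in a functional assay on MDA-MB-231 cells (Homo sapiens) for antiproliferative activity, read by sulforhodamine B assay, with a stated time of 48 h; a higher number here means a weaker inhibitor, a lower number a stronger inhibitor:
compound 1 `COc1cc(OC)c2sc(-c3ccc(N/C=C\C(=O)c4ccc(OC)c(O)c4)c(C)c3)nc2c1`: 3100 nM
compound 2 `COc1ccc(C(=O)/C=C\Nc2ccc(-c3nc4cc(OC)c(OC)c(OC)c4s3)cc2C)cc1O`: 12400 nM
compound 3 `COc1ccc2nc(-c3ccc(N/C=C\C(=O)c4ccc(OC)c([N+](=O)[O-])c4)cc3)sc2c1`: 17600 nM

Compound 1 and compound 2 differ in one place, (methoxy in place of hydrogen on an aromatic carbon), and that step reads a 4.0-fold higher number from compound 1 to compound 2 (0.60 log units; beyond the scatter). Compound 3 carries a different core; the difference between the core of compound 1 and the core of compound 3 is not broken down here. Compound 3 and compound 2 lie within the usual scatter of each other in this assay, so no order is read between them; compound 3 does sit beyond the scatter away from compound 1.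

Compound 4 `COc1ccc2nc(-c3ccc(N/C=C\C(=O)c4cc(OC)c(OC)c([N+](=O)[O-])c4)cc3)sc2c1` is not yet measured. It differs from compound 3 by methoxy in place of hydrogen on an aromatic carbon. This is the same kind of change as from compound 1 to compound 2, but not the same: in compound 2 the new methoxy stands on a ring that is part of a fused or bridged system of two rings, ortho to two methoxy groups, meta to a fused ring and para to a fused ring; in compound 4 it stands on a six-membered aromatic ring of carbon only, ortho to a methoxy group, meta to a large group and meta to a nitro group.

Among the compounds with values here, only one measured instance of this kind of change exists, and its place is not the same, so the expectation for compound 4 rests on the single step of a 4.0-fold higher number from compound 1 to compound 2 (0.60 log units; beyond the scatter) and is held loosely. The step from compound 3 to compound 4 in this assay is expected to be a 1.6-fold higher number from compound 3 to compound 4 (0.20 log units; within the scatter), set smaller than the earlier one and with wide uncertainty. Compound 4 is estimated at 28000 nM, with a likely range from 9000 nM to 70000 nM.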

Compound 4, half-maximal inhibitory concentration: 7610 nM
Compound 4: middle estimate off by 3.7-fold (0.57 log units), on the high side; measured number below the stated range.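

In this assay, methoxy in place of hydrogen on an aromatic carbon gives a 2.3-fold lower number from compound 3 to compound 4 (0.36 log units; beyond the scatter), and the two measured instances of this change do not agree in direction: the same change on two cores in this assay, a 4.0-fold higher number (0.60 log units; beyond the scatter) from compound 1 to compound 2 and a 2.3-fold lower number (0.36 log units; beyond the scatter) from compound 3 to compound 4, 9.3-fold (0.97 log units) apart, beyond the scatter of two such steps

For these two pairs, then, neither the direction nor the size of the step seen on one core carries over to the other, and the earlier step is no safe guide to the effect of this change elsewhere in the series. Within the data shown here, this does not show that the core alone sets the outcome, since the new methoxy also stands in a different place in each pair, and in compound 4 it lies on a six-membered aromatic ring of carbon only, ortho to a methoxy group and meta to a nitro group, so the two factors cannot be separated with only two pairs.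

The compounds shown leave open whether the step would keep its direction if the methoxy entered at one fixed place while only the core changed. They also leave open whether the lower number for compound 4 would persist with an amine or a carboxylic acid standing where the nitro group stands.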